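The source may hold more compounds than are shown below. What is called first, only, known or untested is meant among the compounds shown, and "the series" means these compounds.

Of the compounds shown here, two sharing one core have been measured in an assay on membranes from Sf9 cells for displacement of a labelled ligand from histamine H2 receptor (Homo sapiens), read by scintillation counting, with a stated time of 60 min; a lower number here means a stronger inhibitor, a higher number a weaker inhibitor. Compound 1 `Cc1nc(N)sc1CCCN/C(N)=N/C(=O)N[C@@H](C)c1ccccc1` gives 51.3 nM. Compound 2 `Cc1ccc(C(C)NC(=O)/N=C(\N)NCCCc2sc(N)nc2C)cc1` gives 30.9 nM in this assay, the lowest of the two numbers; compound 1 is its nearest neighbour, and the gap between them lies within the scatter, so neither can be called the stronger binder. Compound 3 `Cc1nc(N)sc1CCCN/C(N)=N/C(=O)NC(C)c1cccs1` has not yet been measured. It differs from compound 2 in one place: thiophen-2-yl in place of 4-methylphenyl on a saturated chain carbon bound to an amide-type nitrogen and a saturated chain carbon. Within the data shown here, no measured pair shows this change, so its effect is unknown from the data at hand. The two measured compounds sit close together, which gives no sign of a large swing. The step from compound 2 to compound 3 is expected to be a 1.5-fold higher number from compound 2 to compound 3 (0.16 log units; within the scatter), a shift not beyond the scatter. Compound 3 is therefore estimated at 45 nM in this assay. Compound 3 is expected to fall between 15 nM and 140 nM.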

Compound 3, inhibition constant: 63.1 nM
Compound 3: the middle estimate sits 1.4-fold (0.15 log units) below what was measured, and the stated range covers the measured number.
By their numbers in this assay, from the lowest: compounds 2, 1 and 3 (each within the scatter of the next, the first and the last beyond it).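

In this assay, among these compounds, thiophen-2-yl in place of 4-methylphenyl gives a 2.0-fold higher number from compound 2 to compound 3 (0.31 log units; beyond the scatter), the first step on this saturated chain carbon that lies beyond the scatter, so a change of ring here can register in binding, though only modestly. Against the 1-phenylethyl group, the 1-(thiophen-2-yl)ethyl group gives a 1.2-fold higher number from compound 1 to compound 3 (0.09 log units; within the scatter), so the five-membered ring with its sulfur cannot be told apart from an unsubstituted phenyl ring, and the gap appears only against 4-methylphenyl. No measurement shown gives a reason for either step.

On these data alone, it remains open whether this carbon needs an aromatic ring at all, which a cyclohexyl ring or a plain methyl group would test. Pyridin-2-yl would show whether a ring nitrogen is accepted here.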